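From compound 2 to compound 4

This account rests on a few compounds, and the source may have more. Where it says the series, first, only, none or still open, it means among the compounds named here.

Compound 1 `Cc1cn2c(/C=N/NC(=N)N)c(-c3ccsc3)nc2s1` gives 7760 nM
Compound 2 `N=C(N)N/N=C/c1c(-c2cc(Cl)sc2Cl)nc2n1CCS2` gives 10200 nM
Compound 3 `N=C(N)N/N=C/c1c(-c2ccsc2)nc2sccn12` gives 6920 nM

In a functional assay on cells (Leukemia cell, Homo sapiens) for inhibition (a lower number here means a stronger inhibitor of growth, a higher number a weaker inhibitor of growth), compound 2 gives 10200 nM, a number within the scatter of both other measured compounds. Compound 4 `N=C(N)N/N=C/c1c(-c2ccsc2)nc2n1CCS2` differs from compound 2 in one place: thiophen-3-yl in place of 2,5-dichlorothiophen-3-yl on an aromatic carbon. In words, thiophen-3-yl stands in place of 2,5-dichlorothiophen-3-yl on an aromatic carbon.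

For the measured compounds named here, no measured step covers this change directly. Going by the values given here, the only measured step, a 1.1-fold lower number from compound 1 to compound 3 (0.05 log units; within the scatter), is a different change, hydrogen in place of methyl on an aromatic carbon, and it stays within the scatter. Compound 3 already carries thiophen-3-yl on a different core and gives 6920 nM, and compound 1 also carries it and gives 7760 nM. Both values lie within the scatter of compound 2, so no step beyond the scatter is expected, though this rests on indirect evidence. The expected size is a 1.3-fold lower number from compound 2 to compound 4 (0.11 log units; within the scatter). For compound 4 the estimated value is 8000 nM, with an expected range from 3800 nM to 17000 nM.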

Compound 4, concentration for 50% growth inhibition: 19100 nM
The estimate for compound 4 lay 2.4-fold (0.38 log units) below the measured number; the measured number lies above the stated range.
By their numbers in this assay, from the lowest: compounds 3, 1, 2 and 4 (each within the scatter of the next, the first and the last beyond it).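

In this assay, for the compounds shown here, the pair gives the first direct reading of the aryl group on an aromatic carbon of this core, with a 1.9-fold higher number from compound 2 to compound 4 (0.27 log units; within the scatter) as thiophen-3-yl stands in place of 2,5-dichlorothiophen-3-yl. Going by these compounds alone, on this core, then, the two chlorine atoms can be absent without a step beyond the scatter, whereas the only earlier step concerned a methyl group at another place on a different core. Nothing available gives a reason for this result.

The compounds shown leave open whether a single chlorine atom on the thiophene would read differently from the two together. They also leave open whether a phenyl ring, an amine or a carboxylic acid at this position would move the number beyond the scatter.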